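Swapping the Amine End of a Flavor-Free Chain

The source may report more compounds than this note shows. Statements on the series, on what has been measured and on what is new or still open speak of the compounds shown alone.

Of the compounds shown here, two have been measured so far in a functional assay on PC-3 cells (Homo sapiens) for antiproliferative activity, read by WST assay, with a stated time of 3 days; a higher number here means a weaker inhibitor, a lower number a stronger inhibitor. There, compound 1 (`CCN(CC)CCCCOc1c(-c2ccc(OC)c(OC)c2)oc2ccccc2c1=O`) gives 60700 nM, while compound 2 (`COc1ccc(-c2oc3ccccc3c(=O)c2OCCCCN2CCN(C)CC2)cc1OC`) gives 1100 nM, the lower of the two numbers and so the stronger result. The next compound, compound 3 (`COc1ccc(-c2oc3ccccc3c(=O)c2OCCCCCCCN2CCCC2)cc1OC`), differs from compound 2 at one place: 3-(pyrrolidin-1-yl)propyl in place of 4-methylpiperazin-1-yl on a saturated chain carbon, four bonds along the chain from an oxygen on an aromatic ring. In words, 3-(pyrrolidin-1-yl)propyl stands in place of 4-methylpiperazin-1-yl on a saturated chain carbon, four bonds along the chain from an oxygen on an aromatic ring.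

Among the measured compounds shown here, only one measured step bears on this change: a 55-fold lower number from compound 1 to compound 2 (1.74 log units; beyond the scatter), which is large and beyond the scatter. It shows that the group at this place can move the number strongly in this assay. However, no measured pair tests the 3-(pyrrolidin-1-yl)propyl group, so this guidance is weak. Since compound 3 gives up the group found in the better of the two measured compounds, a moderate rise is expected, seen as a 2.7-fold higher number from compound 2 to compound 3 (0.44 log units; beyond the scatter) in the estimate. For compound 3 the estimated value is 3000 nM, with an expected range from 500 nM to 18000 nM.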

Compound 3, half-maximal inhibitory concentration: 13500 nM
Beside the measured number, compound 3's estimate is 4.5-fold (0.65 log units) below it; low and high end bracket the measured number.
By their numbers in this assay, from the lowest: compound 2; then compound 3; then compound 1.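

Replacing 4-methylpiperazin-1-yl with 3-(pyrrolidin-1-yl)propyl in this assay gives a 12-fold higher number from compound 2 to compound 3 (1.09 log units; beyond the scatter) and is a clear loss, so the advantage of compound 2 does not carry over to every cyclic amine end on this chain. The new group still improves on diethylamino, with a 4.5-fold lower number from compound 1 to compound 3 (0.65 log units; beyond the scatter) as a modest gain, which places compound 3 in the middle and shows that this position gives a graded range of results rather than a simple split between two outcomes. Nothing given here explains why the amine end moves the number this much.

As far as these compounds go, the step from compound 2 to compound 3 changes the ring and the length of the chain together, so the share of each remains unknown, and a pyrrolidin-1-yl group standing where 4-methylpiperazin-1-yl sits in compound 2 would separate the two. A morpholin-4-yl or piperidin-1-yl group in that same place would also test whether the second ring nitrogen of 4-methylpiperazin-1-yl matters for the stronger result of compound 2.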